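The compounds below may be only part of what the source reports. "The series", "measured", "known", "first", "only" and "open" are said of these compounds alone.

Of the compounds shown here, three have been measured in a functional assay on CHO cells for agonist activity at 5-hydroxytryptamine receptor 4 (Homo sapiens), read by a luciferase reporter and cAMP accumulation, with a stated time of 4 h; on this read-out lower numbers stand for smaller maximal responses and higher numbers for larger maximal responses. Compound 1 `CC(C)c1nc(C(=O)NCC2CCN(C3CCOCC3)CC2)c2ccccn12` gives 29% in this assay, and compound 2 `CC(C)c1nc(C(=O)NCC2CCN(C3CCC3)CC2)c2ccccn12` gives 20%. These two share one core and differ only in the group carried by the ring amine nitrogen: oxan-4-yl in place of cyclobutyl on an amine nitrogen in a ring. The step of a number 9 percentage points higher from compound 2 to compound 1 (within the scatter) is small.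

Compound 3 `CC(C)c1nc(C(=O)NC[C@@H]2[C@H]3CN(C4CCC4)C[C@@H]23)c2ccccn12` is built on a different core. The difference between the two cores is not broken down here. In this assay compound 3 gives 59%, the largest response of the three.

Compound 4 `CC(C)c1nc(C(=O)NC[C@@H]2[C@H]3CN(C4CCOCC4)C[C@@H]23)c2ccccn12` has not yet been measured. It stands to compound 3 as compound 1 stands to compound 2: oxan-4-yl in place of cyclobutyl on an amine nitrogen in a ring. The place is not the same word for word. In compound 2 the nitrogen sits in a six-membered non-aromatic ring with 1 nitrogen, with three ring bonds from the ring atom that bears a large group; in compound 3 it sits in a five-membered non-aromatic ring with 1 nitrogen, part of a fused or bridged system of two rings, with two ring bonds from two ring atoms that each bear a fused ring. So this is the same kind of change, not the same change.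

Since the earlier instance of this change moved the response only within the scatter, the step expected for compound 4 is a number 5 percentage points higher from compound 3 to compound 4 (within the scatter), resting on compound 3 at 59% and on the small step of a number 9 percentage points higher from compound 2 to compound 1 (within the scatter). Compound 4 is therefore expected to give about 64%, most likely between 45% and 82%, in this assay.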

Compound 4, largest response reached (Emax), in percent of the reference or control that the assay uses: 43%
The estimate for compound 4 lay 21 percentage points above the measured number, and the stated range ends above it.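

In this assay, putting oxan-4-yl in place of cyclobutyl on the amine nitrogen of the five-membered ring gives a number 16 percentage points lower from compound 3 to compound 4 (beyond the scatter), a modest loss of maximal response on this core. Set beside the same change on the core of compound 1, it shows that the change does not carry over as a fixed step from one core to the other: the same change on two cores in this assay, a number 9 percentage points higher (within the scatter) from compound 2 to compound 1 and a number 16 percentage points lower (beyond the scatter) from compound 3 to compound 4, 25 percentage points apart, beyond the scatter of two such steps. The comparison rests on a single pair of compounds for each core, so it shows that the size and direction of the step can differ with the core in this series, but it does not show what in the cores produces the difference or what the step would be on a third core.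

The compounds shown carry only cyclobutyl and oxan-4-yl on the ring nitrogen, so it remains open how a small group such as methyl, a longer alkyl chain or a ring containing a second amine would behave on either core. Going by these compounds, it also remains open whether such groups would differ between the two cores as these two do, or would give the same step on both.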